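The source may report more compounds than this note shows. Statements on the series, on what has been measured and on what is new or still open speak of the compounds shown alone.

Compound 1, `COc1cc(-c2nn(-c3cccc(NC(=O)Nc4cc(C(F)(F)F)cc(C(F)(F)F)c4)c3)cc2-c2ccncc2)ccc1Cl`, gives > 50000 nM in a functional assay on SR cells (Homo sapiens) for inhibition, read by sulforhodamine B assay, with a stated time of 48 h (on this read-out lower numbers stand for higher toxicity in this test and higher numbers for lower toxicity in this test), a value that is a limit of the test and not a number.
Compound 2, `O=C(Nc1cccc(-n2cc(-c3ccncc3)c(-c3ccc(Cl)c(O)c3)n2)c1)Nc1cc(C(F)(F)F)cc(C(F)(F)F)c1`, gives > 50000 nM in this assay, again a limit.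
Compound 3, `COc1cc(-c2nn(-c3cccc(NC(=O)Nc4ccc(Cl)c(C(F)(F)F)c4)c3)cc2-c2ccncc2)ccc1Cl`, gives > 32500 nM in this assay, also a limit.

Compound 2 differs from compound 1 by hydrogen in place of methyl on an oxygen on an aromatic ring. Both values are limits, so the step that the two limits leave unreadable from compound 1 to compound 2 cannot be sized: the limit of > 50000 nM in this assay, at which 2 of the 3 values shown sit.

Compound 4, `O=C(Nc1cccc(-n2cc(-c3ccncc3)c(-c3ccc(Cl)c(O)c3)n2)c1)Nc1ccc(Cl)c(C(F)(F)F)c1`, has not been measured. It differs from compound 3 by hydrogen in place of methyl on an oxygen on an aromatic ring, the same change as from compound 1 to compound 2, at the same place. Compound 3 differs from compound 1 in its core, a difference that is not broken down here; compound 3 sits at its own limit, (the limit of > 32500 nM in this assay, at which 1 of the 3 values shown sits).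

With all three measured values limits, the step from compound 3 to compound 4 is expected to be unreadable as well, and compound 4 is expected to sit at the limit again, a step that the limit leaves unreadable from compound 3 to compound 4. The estimate for compound 4 is 50000 nM, with a range from 20000 nM to 120000 nM.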

Compound 4, concentration lethal to 50% of the cells: > 32500 nM
Compound 4 ended at the assay's limit; the forecaster's own chance of this, stated with the estimate: 85%; the middle value is on the limit's open side.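

No new step can be read: compound 3 and compound 4 both stand at a limit of the test and not at a number, so the change from methoxy to hydroxy between them has no readable size. The compounds shown leave open at what concentration any of them would reach the lethal mark in this assay, and whether that change affects it.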